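Aminoquinoline ethers at the melanin-concentrating hormone receptor

This account rests on a few compounds, and the source may have more. Where it says the series, first, only, none or still open, it means among the compounds named here.

Measured so far:
compound 1, `Nc1ccc2cccc(OCC3CCCC3)c2n1`: 53 nM
compound 2, `Nc1ccc2cccc(OCC3CC4CCC3C4)c2n1`: 137 nM
compound 3, `CCC(CC)C(C)Oc1cccc2ccc(N)nc12`: 191 nM

The three compounds share one core and differ only in the group carried by the ether oxygen. In an assay on cells with melanin-concentrating hormone receptor 1 (Homo sapiens) as the target, read by radioligand binding (on this read-out lower numbers stand for stronger inhibition and higher numbers for weaker inhibition), compound 1 gives the lowest number of the three; its nearest neighbour, compound 2, lies beyond the scatter, and compound 3 stands further off still. Nothing here ties a single structural change to a measured step, so the account rests on the three values alone.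

The next compound, compound 4, `CSCCOc1cccc2ccc(N)nc12`, keeps the core of compound 1 and alters the ether chain: (methylsulfanyl)methyl in place of cyclopentyl on a saturated chain carbon bound to an oxygen on an aromatic ring. Cut one bond further out, the same change reads cyclopentylmethyl to 2-(methylsulfanyl)ethyl.

Both alterations of the chain seen so far, in compound 2 and compound 3, moved the number in this assay upward from compound 1, so a step upward beyond the scatter is expected here as well. Compound 4 is therefore estimated at 220 nM, within 60 nM to 800 nM, a step of a 4.2-fold higher number from compound 1 to compound 4 (0.62 log units; beyond the scatter).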

Compound 4, half-maximal inhibitory concentration: > 2000 nM
Compound 4: a limit, no number; the forecaster's own chance of this, stated with the estimate: 5%; middle value at least 9.0-fold (0.95 log units) from the limit.
By their numbers in this assay, from the lowest: compound 1; then compounds 2 and 3 (each within the scatter of the next). At a limit, above all of these: compound 4.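

Compound 4 stands at a limit of this assay, not at a number: the limit of > 2000 nM in this assay, at which 1 of the 4 values shown sits.

Replacing cyclopentyl with (methylsulfanyl)methyl on a saturated chain carbon bound to an oxygen on an aromatic ring gives an at least 37-fold higher number from compound 1 to compound 4 (1.57 log units; beyond the scatter), a large step and the first in this series that ties a single change in the ether chain to a measured result. Of the four ether groups shown, only the 2-(methylsulfanyl)ethyl chain of compound 4 leaves the read-out at a limit, so the result at this position clearly depends on the group it carries.

This one change removes the ring, shortens the group from 5 heavy atoms to 3 and brings in sulfur all at once, and the compounds shown cannot tell which of these goes with the large step. As far as these compounds go, a 2-methoxyethyl chain, which has oxygen in place of the sulfur, and a plain butyl chain, which has carbon only and no ring, would be needed to pull these apart, and how far compound 4 lies beyond its limit stays open.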